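Moving the Nitrile Around the Aryl Ring of Compound 1

The compounds below may be only part of what the source reports. "The series", "measured", "known", "first", "only" and "open" are said of these compounds alone.

Compound 1 `N#Cc1ccc(/C=N/Nc2nc(N)c3ncn([C@@H]4O[C@H](CO)[C@@H](O)[C@H]4O)c3n2)cc1` has the lowest of the two numbers measured in an assay on CHO-K1 cells for displacement of a labelled ligand from adenosine receptor A1 (Homo sapiens), read by scintillation counting, with a stated time of 60 min (on this read-out higher numbers stand for weaker inhibition and lower numbers for stronger inhibition), where compound 1 gives 4.1 nM. Compound 2 `Nc1nc(N/N=C/c2ccc3ncccc3c2)nc2c1ncn2[C@@H]1O[C@H](CO)[C@@H](O)[C@H]1O` gives 9.8 nM in this assay, a step of a 2.4-fold higher number from compound 1 to compound 2 (0.38 log units; beyond the scatter). Compound 3 `Nc1nc(N/N=C/c2ccc(C(F)(F)F)cc2C(F)(F)F)nc2c1ncn2[C@@H]1O[C@H](CO)[C@@H](O)[C@H]1O` reaches only the limit of this assay, > 10000 nM, which is the limit of > 10000 nM in this assay, at which 1 of the 3 values shown sits. Compound 4 `N#Cc1ccccc1/C=N/Nc1nc(N)c2ncn([C@@H]3O[C@H](CO)[C@@H](O)[C@H]3O)c2n1` differs from compound 1 by 2-cyanophenyl in place of 4-cyanophenyl on a carbon with a double bond to nitrogen. Going by the values given here, no measured step keeps the aryl group and moves its substituent, so the pair of compound 1 and compound 2, which exchanges the whole aryl group, is the only guide to the size such an aryl change can take. Compound 4 is therefore expected to give 30 nM, within 6 nM to 200 nM, an estimated step of a 7.3-fold higher number from compound 1 to compound 4 (0.86 log units; beyond the scatter) toward a weaker number.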

Compound 4, inhibition constant: 2.9 nM
Compound 4: the middle estimate sits 10-fold (1.01 log units) above what was measured, outside the stated range (below it).
By their numbers in this assay, from the lowest: compounds 4 and 1 (each within the scatter of the next); then compound 2. At a limit, above all of these: compound 3.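

In this assay the nitrile position on the aryl ring proves open to change: 2-cyanophenyl in place of 4-cyanophenyl gives a step of a 1.4-fold lower number from compound 1 to compound 4 (0.15 log units; within the scatter) and so leaves the number unchanged. The step of a 3.4-fold lower number from compound 2 to compound 4 (0.53 log units; beyond the scatter) shows that the modest gap to quinolin-6-yl remains with the nitrile at this new position. Nothing measured here accounts for this result.

As far as these compounds go, whether 3-cyanophenyl would behave in the same way remains open. So does whether an amine or a carboxylic acid could take the place of the nitrile on this ring.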